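This account rests on a few compounds, and the source may have more. Where it says the series, first, only, none or still open, it means among the compounds named here.

In a functional assay on the whole organism for inhibition, with Mus musculus as the target (a higher number here means that more compound is needed for the effect, a lower number that less compound is needed), compound 2 `CCOC(=O)Nc1cccc2c1CN(C)CC2c1ccccc1` gives 3.2 mg/kg as its dose, and compound 3 `CCCCOC(=O)Nc1cccc2c1CN(C)CC2c1ccccc1` gives 4 mg/kg on the same scale. These two belong together, as a 1.3-fold higher number from compound 2 to compound 3 (0.10 log units; within the scatter) shows. Compound 1 `CCCNC(=O)Nc1cccc2c1CN(C)CC2c1ccccc1` gives > 80 mg/kg as its reading, which is a limit of the assay and not a number. Compound 3 therefore stands level with compound 2 and well away from that limit.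

Within the data shown here, compound 4 `CCNCC(=O)Nc1cccc2c1CN(C)CC2c1ccccc1` carries (ethylamino)methyl in place of butoxy on a carbonyl carbon as its one change. Among the measured compounds shown here, two measured steps bear on this swap, and both are large: an at least 25-fold lower number from compound 1 to compound 2 (1.39 log units; beyond the scatter) and an at least 20-fold lower number from compound 1 to compound 3 (1.30 log units; beyond the scatter) in each case replace propylamino with an alkoxy group. Compound 4 gives up its alkoxy group, so on the strength of an at least 20-fold lower number from compound 1 to compound 3 (1.30 log units; beyond the scatter) a rise in the number is expected. Yet (ethylamino)methyl is not propylamino, so only part of that size is expected. The expected change is a 3.8-fold higher number from compound 3 to compound 4 (0.57 log units; beyond the scatter) in this assay as an estimate. For compound 4 the estimated dose is 15 mg/kg within a range of 3 mg/kg to 80 mg/kg in this estimate.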

Compound 4, dose for half-maximal effect: 47 mg/kg
For compound 4 the middle estimate is 3.1-fold (0.50 log units) below the measured one; the range from low to high includes it.
By their numbers in this assay, from the lowest: compounds 2 and 3 (each within the scatter of the next); then compound 4. At a limit, above all of these: compound 1.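

Among these compounds, on the carbonyl carbon, alkoxy had so far been set only against propylamino; (ethylamino)methyl now gives a second group that carries nitrogen instead, and it too reads well apart from both alkoxy compounds in this assay: a 12-fold higher number from compound 3 to compound 4 (1.07 log units; beyond the scatter) and a 15-fold higher number from compound 2 to compound 4 (1.17 log units; beyond the scatter). Compound 1 stands at a limit of the assay, which is not a number: the limit of > 80 mg/kg in this assay, at which 1 of the 4 values shown sits. Going by these compounds, its step to the new compound, an at least 1.7-fold lower number from compound 1 to compound 4 (0.23 log units; that floor lies within the scatter), gives only a floor, so the order of these two nitrogen-bearing compounds stays open.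

The compounds shown leave open how a plain butyl chain, with neither oxygen nor nitrogen, would read on this carbonyl carbon. They also leave open how (dimethylamino)methyl would read, with no hydrogen left on its nitrogen.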